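The source may hold more compounds than are shown below. What is called first, only, known or untested is meant among the compounds shown, and "the series" means these compounds.

Compound 1 `Cc1cc(N2CC[C@@H](C)[C@@H](N(C)c3ncnc4[nH]ccc34)C2)n2nc(SCc3ccccc3)nc2n1` carries the unsubstituted benzylsulfanyl group. In a toxicity assay on GES1 cells (Homo sapiens) for inhibition, read by MTT assay, with a stated time of 72 h (a lower number here means a stronger inhibitor, a higher number a weaker inhibitor), compound 1 gives 67200 nM, the highest of the two numbers shown. Compound 3 `Cc1cc(N2CC[C@@H](C)[C@@H](N(C)c3ncnc4[nH]ccc34)C2)n2nc(SCc3ccc(F)cc3)nc2n1`, with a fluoro on the ring, gives 12300 nM in this assay. Compound 2 `Cc1cc(N2CC[C@@H](C)[C@@H](N(C)c3ncnc4[nH]ccc34)C2)n2nc(SCc3ccc(Cl)cc3)nc2n1` reaches only a limit of the assay, > 100000 nM, in this assay. That limit is noted as the limit of > 100000 nM in this assay, at which 1 of the 3 values shown sits. The two halogens thus moved the readout in opposite directions: an at least 1.4-fold higher number from compound 1 to compound 2 (0.17 log units; that floor lies within the scatter), whereas a 5.5-fold lower number from compound 1 to compound 3 (0.74 log units; beyond the scatter), and an at least 8.1-fold lower number from compound 2 to compound 3 (0.91 log units; beyond the scatter).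

Compound 4 `Cc1cc(N2CC[C@@H](C)[C@@H](N(C)c3ncnc4[nH]ccc34)C2)n2nc(SCc3ccc([N+](=O)[O-])cc3)nc2n1` differs from compound 1 by nitro in place of hydrogen on an aromatic carbon. Among the measured compounds shown here, no measured step involves a nitro group, and the two measured para substituents point different ways, one weakening and one modestly strengthening. The nitro case is therefore left open by the data, and the account stays close to the parent while allowing for both outcomes. Compound 4 is expected to give about 50000 nM in this assay, within a range from 15000 nM to 100000 nM. For compound 4 this estimate means a 1.3-fold lower number from compound 1 to compound 4 (0.13 log units; within the scatter) is expected.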

Compound 4, half-maximal inhibitory concentration: 36600 nM
Compound 4: the middle estimate sits 1.4-fold (0.14 log units) above what was measured, and the stated range covers the measured number.
By their numbers in this assay, from the lowest: compound 3; then compounds 4 and 1 (each within the scatter of the next). At a limit, above all of these: compound 2.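

In this assay, a third group in this place on the benzyl ring, para to a large group, gives a step that does not separate the new compound from the parent: a 1.8-fold lower number from compound 1 to compound 4 (0.26 log units; within the scatter). The fluoro and chloro compounds both remain apart from the nitro compound, with a 3.0-fold higher number from compound 3 to compound 4 (0.47 log units; beyond the scatter) and an at least 2.7-fold lower number from compound 2 to compound 4 (0.43 log units; beyond the scatter), so among the groups shown only compound 3 stands clearly below the parent, while compound 2 stands clearly above compound 4. The reading for compound 2 is a limit and not a number: the limit of > 100000 nM in this assay, at which 1 of the 4 values shown sits.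

As far as these compounds go, whether an amine or a carboxylic acid in this place would read like compound 1 or like compound 3 stays open. So does the effect of a longer chain in place of the benzyl group.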